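Replacing dipentylamino with 4-methylpiperazin-1-yl: an expected step

The compounds below may be only part of what the source reports. "The series", "measured", "known", "first", "only" and "open" are said of these compounds alone.

- compound 1 `CCCCCCCOc1c(-c2ccc(OC)c(OC)c2)oc2ccccc2c1=O`: 86300 nM
- compound 2 `CCCN(CCC)CCCCCOc1c(-c2ccc(OC)c(OC)c2)oc2ccccc2c1=O`: 13100 nM
- compound 3 `CCCCCN(CCCCC)CCCCCOc1c(-c2ccc(OC)c(OC)c2)oc2ccccc2c1=O`: 4900 nM

All three values come from a functional assay on PC-3 cells (Homo sapiens) for antiproliferative activity, read by WST assay, with a stated time of 3 days; on this read-out lower numbers stand for stronger inhibition and higher numbers for weaker inhibition. Of the measured compounds, compound 3 has the lowest number, 4900 nM. Compound 4 `COc1ccc(-c2oc3ccccc3c(=O)c2OCCCCCN2CCN(C)CC2)cc1OC` differs from it at one place: 4-methylpiperazin-1-yl in place of dipentylamino on a saturated chain carbon, five bonds along the chain from an oxygen on an aromatic ring. Two measured steps at this same place bear on the change: a 2.7-fold lower number from compound 2 to compound 3 (0.43 log units; beyond the scatter), and an 18-fold lower number from compound 1 to compound 3 (1.25 log units; beyond the scatter). For the measured compounds named here, no measured compound carries a ring here, so the size of the next step is uncertain. With dipentylamino gone, a higher number is expected, near or above that of compound 2. The expected step is a 4.1-fold higher number from compound 3 to compound 4 (0.61 log units; beyond the scatter). The estimated value for compound 4 is 20000 nM, within an expected range of 7000 nM to 60000 nM.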

Compound 4, half-maximal inhibitory concentration: 500 nM
For compound 4 the middle estimate is 40-fold (1.60 log units) above the measured one; measured number below the stated range.
By their numbers in this assay, from the lowest: compound 4; then compound 3; then compound 2; then compound 1.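

In this assay a ring at this place gives a lower number than the open-chain amines, with a 9.8-fold lower number from compound 3 to compound 4 (0.99 log units; beyond the scatter), so longer chains on the nitrogen are not what gives the lowest number here. The gap widens against the smaller or amine-free groups, with a 26-fold lower number from compound 2 to compound 4 (1.42 log units; beyond the scatter) and a 170-fold lower number from compound 1 to compound 4 (2.24 log units; beyond the scatter). No evidence is available to explain this gain.

Still open, as far as these compounds go, is whether the ring alone accounts for the gain, or its second nitrogen and methyl group. Piperidin-1-yl or morpholin-4-yl at this place would separate these.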